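The compounds below may be only part of what the source reports. "The series", "measured", "known", "first", "only" and "open" are said of these compounds alone.

Among the compounds with values here, compound 2 `C/C(=N\NC(=O)Nc1ccc(Br)cc1)c1ccccc1` stands as the stronger of the two compounds measured so far in a functional assay on the whole organism with Mus musculus as the target, in the maximal electroshock model, with a stated time of 0.5 h; a higher number here means that more compound is needed for the effect, a lower number that less compound is needed. In this assay compound 2 gives 100 mg/kg. Within the data shown here, the only other measured compound, compound 1 `COc1ccc(/C=N/NC(=O)Nc2ccc(Br)cc2)cc1OC`, gives 300 mg/kg in this assay, a higher number lying beyond the usual scatter, so compound 2 needs less material for the same protective effect. Compound 3 `C/C(=N\NC(=O)Nc1ccc(Br)cc1)c1ccc(O)cc1` has not yet been measured. It differs from compound 2 in a single place: hydroxy in place of hydrogen on an aromatic carbon. Among the measured compounds shown here, no pair of measured compounds shows this same change, so the numbers gathered so far give no direct guide to its size. Compound 3 is expected to give about 100 mg/kg in this assay, with a range from 50 mg/kg to 300 mg/kg. The step of no change at the digits printed from compound 2 to compound 3 (within the scatter) is therefore expected to be none beyond the scatter, though a modest move in either direction would not surprise.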

Compound 3, minimum effective dose: 300 mg/kg
Compound 3: the middle estimate sits 3.0-fold (0.48 log units) below what was measured, and the stated range covers the measured number.
By their numbers in this assay, from the lowest: compound 2; then compounds 1 and 3 (each within the scatter of the next).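

In this assay, the change from phenyl to 4-hydroxyphenyl brings a 3.0-fold higher number from compound 2 to compound 3 (0.48 log units; beyond the scatter), so more compound is needed once hydroxy stands on this aromatic carbon, para to a large group. Within the data shown here, this is the first single change that can be read, and it shows that this position responds to a group of only 1 heavy atom. Nothing measured here gives a reason for the shift, so its cause remains unknown.

Still open, on these data alone, is whether the rise belongs to hydroxy alone or would also follow other groups in this place, such as an amine, a fluorine or a carboxylic acid. Also open, as far as these compounds go, is whether hydroxy on another carbon of the ring, or on a different core, would move the number in the same way.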